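The compounds below may be only part of what the source reports. "The series", "measured", "known", "first", "only" and "open" are said of these compounds alone.

Working notes on the series. In an in vitro ADME assay on microsomes from Gut (Homo sapiens) for metabolic stability, in the presence of a further agent that is not named here (on this read-out lower numbers stand for slow clearance and higher numbers for fast clearance), compound 1 `N#Cc1ccc2c(c1)cc(C(=O)NCCC(O)(C(F)(F)F)C(F)(F)F)n2Cc1cccc(OC(F)(F)F)c1` gives < 6 mL.min-1.g-1, which is a limit and not a number. Compound 2 `N#Cc1ccc2c(c1)cc(C(=O)NCCC1(O)CCC1)n2Cc1cccc(OC(F)(F)F)c1` gives < 6 mL.min-1.g-1, which is also a limit and not a number. Compound 2 therefore sits at the limit of < 6 mL.min-1.g-1 in this assay, at which 2 of the 2 values shown sit, and has no exact value to build on.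

The change to compound 3 `CC(O)C1(CNC(=O)c2cc3cc(C#N)ccc3n2Cc2cccc(OC(F)(F)F)c2)CCCC1` is a group of 8 heavy atoms (7 carbon, 1 oxygen; one five-membered non-aromatic ring of carbon only) in place of a group of 6 heavy atoms (5 carbon, 1 oxygen; one four-membered non-aromatic ring of carbon only), on a saturated chain carbon bound to an amide-type nitrogen. A five-membered non-aromatic ring of carbon only thus replaces a four-membered one, on a saturated chain carbon bound to an amide-type nitrogen.

Going by the values given here, the only measured step, a step that the two limits leave unreadable from compound 1 to compound 2, hands on no size, so no change beyond the scatter is expected in this assay. The expected step is a number no lower from compound 2 to compound 3 (the limit leaves the size open), and it carries no firm direction. For compound 3 the estimated value is 6 mL.min-1.g-1, with an expected range of 3 mL.min-1.g-1 to 12 mL.min-1.g-1.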

Compound 3, intrinsic clearance in microsomes: < 6 mL.min-1.g-1
Compound 3 ended at the assay's limit (the forecaster's own chance of this, stated with the estimate: 65%); the middle value sits exactly at the limit.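

In this assay the result for compound 3 is a limit and not a number, so neither the step from compound 1 nor the step from compound 2 to compound 3 can be read: the limit of < 6 mL.min-1.g-1 in this assay, at which 3 of the 3 values shown sit.

The compounds shown leave open whether the groups on the saturated chain carbon differ at all in this assay, since none has an exact value.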